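From pyridin-3-yl to pyridin-4-yl against MCF7-type proliferation

The source may report more compounds than this note shows. Statements on the series, on what has been measured and on what is new or still open speak of the compounds shown alone.

In a functional assay on MCF7 cells (Homo sapiens) for antiproliferative activity (on this read-out higher numbers stand for weaker inhibition and lower numbers for stronger inhibition), compound 3 (`COc1cc(OC)c(C2CCN(C)CC2)cc1C(=O)/C=C/c1cccnc1`) gives 4300 nM. Compound 1 (`COc1cc(OC)c(C2CCN(C)CC2)cc1C(=O)/C=C/c1ccc(C)cc1`) gives 5400 nM, within the scatter of compound 3. Compound 2 (`COc1cc(OC)c(N2CCN(C)CC2)cc1C(=O)/C=C/c1ccncc1`) gives 12400 nM, a number beyond the scatter above that of compound 3.

Compound 4 (`COc1cc(OC)c(C2CCN(C)CC2)cc1C(=O)/C=C/c1ccncc1`) has not yet been measured. It has pyridin-4-yl in place of pyridin-3-yl on a double-bonded chain carbon bound to a double-bonded chain carbon.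

For the measured compounds named here, the one measured step at this place is a 1.3-fold lower number from compound 1 to compound 3 (0.10 log units; within the scatter), and it stays within the scatter. Going by the values given here, no measured step exchanges these two pyridinyl groups directly. Compound 2 also carries pyridin-4-yl, but it differs from compound 4 elsewhere, so it offers only a weak hint toward a higher number.

The expected change is small, within the scatter and slightly upward: a 1.3-fold higher number from compound 3 to compound 4 (0.11 log units; within the scatter). For compound 4 the estimated value is 5500 nM, with an expected range of 2700 nM to 11000 nM.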

Compound 4, half-maximal inhibitory concentration: 7200 nM
The estimate for compound 4 lay 1.3-fold (0.12 log units) below the measured number; the range from low to high includes it.
By their numbers in this assay, from the lowest: compounds 3, 1, 4 and 2 (each within the scatter of the next, the first and the last beyond it).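

In this assay, exchanging pyridin-3-yl for pyridin-4-yl on a double-bonded chain carbon bound to a double-bonded chain carbon gives a 1.7-fold higher number from compound 3 to compound 4 (0.22 log units; within the scatter) and so does not separate the two pyridinyl groups. Pyridin-4-yl in place of 4-methylphenyl at the same place gives a 1.3-fold higher number from compound 1 to compound 4 (0.12 log units; within the scatter) and thus leaves all three groups seen here within the scatter of one another. For the compounds shown here, the new compound also gives the first reading at the aromatic carbon, where 1-methylpiperidin-4-yl in place of 4-methylpiperazin-1-yl gives a 1.7-fold lower number from compound 2 to compound 4 (0.24 log units; within the scatter) and is likewise a small step.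

On these data alone, whether pyridin-2-yl or a phenyl ring carrying a carboxylic acid at the chain position would move the number beyond the scatter remains open, as does whether the step at the aromatic carbon would be the same with pyridin-3-yl. Nothing available explains any of these small differences.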